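Methyl on an Aromatic Nitrogen, Tried on a Second Core

This account rests on a few compounds, and the source may have more. Where it says the series, first, only, none or still open, it means among the compounds named here.

Three compounds have been measured in an assay on isolated protein for inhibition of MAP kinase-activated protein kinase 2 (Homo sapiens), read by mobility shift assay, tested at 30 uM; on this read-out lower numbers stand for less inhibition and higher numbers for more inhibition at the one concentration tested (going by the name of the read-out):
compound 1, `Nc1n[nH]c2cc(-c3ccccn3)[nH]c(=O)c12`, gives 41%
compound 2, `Cc1cc2[nH]nc(N)c2c(N2CCCCC2)n1`, gives -1%
compound 3, `Cn1nc(N)c2c(=O)[nH]c(-c3ccccn3)cc21`, gives 36%

Compound 3 differs from compound 1 by methyl in place of hydrogen on an aromatic nitrogen, and this change made a number 5 percentage points lower from compound 1 to compound 3 (within the scatter). Compound 2 stands lowest of the three; its number is beyond the scatter from both compound 1 and compound 3. How the core of compound 2 differs from the core of compound 1 is not broken down here.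

Compound 4, `Cc1cc2c(c(N)nn2C)c(N2CCCCC2)n1`, has not yet been measured. It differs from compound 2 by methyl in place of hydrogen on an aromatic nitrogen, the same kind of change as that from compound 1 to compound 3, at a place described in the same words. Since that earlier change stayed within the scatter, the step is expected to be small again: a number 1 percentage points higher from compound 2 to compound 4 (within the scatter) in this assay, resting on a number 5 percentage points lower from compound 1 to compound 3 (within the scatter). Compound 4 is therefore estimated at 0%, with a range from -10% to 10%, because compound 2 gives -1%.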

Compound 4, a percentage reported as inhibition, at one concentration (the size of the read-out at that concentration, not a potency): 7%
For compound 4 the middle estimate is 7 percentage points below the measured one; measured number inside the range.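

In this assay, methyl in place of hydrogen on an aromatic nitrogen gave a number 8 percentage points higher from compound 2 to compound 4 (within the scatter), and set beside the step on the first core, the two cannot be told apart: the same change on two cores in this assay, a number 5 percentage points lower (within the scatter) from compound 1 to compound 3 and a number 8 percentage points higher (within the scatter) from compound 2 to compound 4, 13 percentage points apart, within the scatter of two such steps

So across these two pairs the change carries from one core to the other in a limited sense, as neither step leaves the scatter. This does not show that the methyl is without any effect on either core, and two pairs say nothing about how the change would behave on any further core.

The compounds shown leave open whether an ethyl group, a longer chain or a benzyl group on that same aromatic nitrogen would also stay within the scatter. They also leave open what would follow if a methylamino group or a hydroxyl group took the place of the amino group two ring bonds away.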